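This account rests on a few compounds, and the source may have more. Where it says the series, first, only, none or still open, it means among the compounds named here.

In an in vitro ADME assay on microsomes from liver (Homo sapiens) for metabolic stability (on this read-out higher numbers stand for a longer-lived compound and lower numbers for a shorter-lived compound), two compounds that share one core have been measured so far. Compound 1 `CCC(C)(C)CCn1nc(-c2cccs2)c(O)c(C2=CS(=O)(=O)c3cc(NS(C)(=O)=O)ccc3N2)c1=O` gives 0.5 h, and compound 2 `CS(=O)(=O)Nc1ccc2c(c1)S(=O)(=O)C=C(c1c(O)c(-c3cccs3)nn(CC3CCCC3)c1=O)N2` gives 0.717 h, so compound 2 stands within the scatter of compound 1. Compound 3 `CS(=O)(=O)Nc1ccc2c(c1)S(=O)(=O)C=C(c1c(O)c(-c3cccs3)nn(CC3CC3)c1=O)N2` has not yet been measured. It differs from compound 2 as follows: cyclopropyl in place of cyclopentyl on a saturated chain carbon bound to an aromatic nitrogen. In words, cyclopropyl stands in place of cyclopentyl on a saturated chain carbon bound to an aromatic nitrogen. Going by the values given here, only one measured step bears on this, a change at the same place that puts cyclopentyl in place of 2,2-dimethylbutyl: a 1.4-fold higher number from compound 1 to compound 2 (0.16 log units; within the scatter). That step stays within the scatter, and a single step shows no trend, so no change beyond the scatter is expected in this assay. The expected step is a 1.1-fold higher number from compound 2 to compound 3 (0.05 log units; within the scatter). For compound 3 the estimated half-life is 0.8 h, with an expected range from 0.4 h to 1.6 h.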

Compound 3, half-life: > 1 h
Compound 3 ended at the assay's limit (the forecaster's own chance of this, stated with the estimate: 3%); middle value at least 1.2-fold (0.09 log units) from the limit.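

In this assay, going by these compounds alone, compound 3 is the first compound to end at a limit of the read-out rather than at a number: the limit of > 1 h in this assay, at which 1 of the 3 values shown sits. With cyclopropyl on the saturated chain carbon bound to an aromatic nitrogen, the change from cyclopentyl gives an at least 1.3-fold higher number from compound 2 to compound 3 (0.14 log units; that floor lies within the scatter), and the change from 2,2-dimethylbutyl gives an at least 2.0-fold higher number from compound 1 to compound 3 (0.30 log units; that floor lies within the scatter). Both figures are floors, so this place can tolerate a much smaller ring without any sign of a shorter-lived compound, but the three compounds cannot yet be put in a firm order.

From the compounds shown here alone, how far compound 3 lies past its limit remains open. Also open, going by these compounds, is whether a cyclobutyl ring, a plain ethyl chain or a chain ending in an amine at this place would reach the same limit.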